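The source may report more compounds than this note shows. Statements on the series, on what has been measured and on what is new or still open speak of the compounds shown alone.

Measured compounds:
Compound 1, `Nc1sc(-c2ccc(Cl)cc2)c(-c2ccc(Cl)cc2)c1C(=O)N1CCNCC1`, gives 1020 nM in a functional assay on A549 cells (Homo sapiens) for inhibition, read by sulforhodamine B assay, with a stated time of 72 h; on this read-out lower numbers stand for stronger inhibition and higher numbers for weaker inhibition.
Compound 2, `Nc1sc(-c2ccc(Cl)cc2)c(-c2ccc(Cl)cc2)c1C(=O)NC1CCCC1`, gives 6790 nM in this assay.
Compound 3, `COC(=O)c1c(N)sc(-c2ccc(Cl)cc2)c1-c1ccc(Cl)cc1`, gives 5040 nM in this assay.

All three share the same core and differ only in the group on the carbonyl carbon. Compound 1 stands lowest of the three numbers, so it is the strongest inhibitor of this set. Its two steps lead in the same direction: a 6.7-fold higher number from compound 1 to compound 2 (0.82 log units; beyond the scatter) and a 4.9-fold higher number from compound 1 to compound 3 (0.69 log units; beyond the scatter). Between compound 2 and compound 3 the step is a 1.3-fold lower number from compound 2 to compound 3 (0.13 log units; within the scatter), so those two cannot be told apart.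

Compound 4, `Nc1sc(-c2ccc(Cl)cc2)c(-c2ccc(Cl)cc2)c1C(=O)Nc1ccccc1`, is not yet measured. Compared with compound 1 the change is anilino in place of piperazin-1-yl on a carbonyl carbon. Both measured steps away from compound 1 replaced the piperazin-1-yl group and both raised the number clearly, so the expected direction for compound 4 is the same: a weaker inhibitor than compound 1. The step to cyclopentylamino is the closest guide, as it also introduces a group attached through one nitrogen carrying a hydrogen. The estimated step is a 5.4-fold higher number from compound 1 to compound 4 (0.73 log units; beyond the scatter), and compound 4 is therefore expected to give about 5500 nM, in a range from 2000 nM to 15000 nM.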

Compound 4, half-maximal inhibitory concentration: 25000 nM
Compound 4: the middle estimate sits 4.5-fold (0.66 log units) below what was measured; measured number above the stated range.
By their numbers in this assay, from the lowest: compound 1; then compounds 3 and 2 (each within the scatter of the next); then compound 4.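

The earlier replacements of piperazin-1-yl left compound 2 and compound 3 within the scatter of each other, which could have suggested one common level for other groups on this carbonyl carbon, but compound 4 shows that the number can climb much further: with a 25-fold higher number from compound 1 to compound 4 (1.39 log units; beyond the scatter) in this assay, it is the weakest of the four. The group on the amide nitrogen matters, not only the presence of the amide hydrogen, since cyclopentyl and phenyl both leave that hydrogen in place yet are set apart by a 3.7-fold higher number from compound 2 to compound 4 (0.57 log units; beyond the scatter), and anilino also fares worse than methoxy, with a 5.0-fold higher number from compound 3 to compound 4 (0.70 log units; beyond the scatter). No measurement at hand explains why phenyl gives a higher number than cyclopentyl.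

Still open, going by these compounds, is whether the lower number of compound 1 belongs to the piperazin-1-yl ring as a whole or to one of its nitrogens, a question that piperidin-1-yl and morpholin-4-yl could address. Also open, on these data alone, is whether the higher number of compound 4 goes with the phenyl ring itself or with its direct attachment to the amide nitrogen, which benzylamino, adding one carbon ahead of the same ring, could separate.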